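Trifluoromethyl next to the ring sulfur: compound 3 to compound 4

The source may hold more compounds than are shown below. What is called first, only, known or untested is meant among the compounds shown, and "the series" means these compounds.

Three analogues of the shared core have numbers in a functional assay on cells for agonist activity at Free fatty acid receptor 1 (Rattus norvegicus), read by FLIPR and calcium flux; a lower number here means that less compound is needed, a higher number that more compound is needed for the effect. Compound 1 `CC#C[C@@H](Cc1nnn[nH]1)c1ccc(OCc2ccc3scc(-c4cncnc4C)c3c2)cc1` gives 18 nM. Compound 2 `CC#C[C@@H](Cc1nnn[nH]1)c1ccc(OCc2ccc3scc(-c4ccccc4C(F)(F)F)c3c2)cc1` gives 2 nM, with a 9.0-fold lower number from compound 1 to compound 2 (0.95 log units; beyond the scatter). Compound 3 `CC#C[C@@H](Cc1nnn[nH]1)c1ccc(OCc2ccc3scc(-c4ccc(OCCOC)cc4C)c3c2)cc1` gives 4 nM, the second highest of the three numbers, with a 4.5-fold lower number from compound 1 to compound 3 (0.65 log units; beyond the scatter) and a 2.0-fold higher number from compound 2 to compound 3 (0.30 log units; within the scatter). Compound 4 `CC#C[C@@H](Cc1nnn[nH]1)c1ccc(OCc2ccc3sc(C(F)(F)F)c(-c4ccc(OCCOC)cc4C)c3c2)cc1` is unmeasured; it differs from compound 3 by trifluoromethyl in place of hydrogen on an aromatic carbon. For the measured compounds named here, every measured step exchanges the 4-methylpyrimidin-5-yl, 2-(trifluoromethyl)phenyl or 4-(2-methoxyethoxy)-2-methylphenyl group and leaves the hydrogen next to the ring sulfur untouched, so no measured step bears on this change. In this assay compound 4 is therefore expected to show no change at the digits printed from compound 3 to compound 4 (within the scatter), nothing beyond the scatter, because compound 3 gives 4 nM. Compound 4 is estimated at 4 nM, range 1.3 nM to 12 nM.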

Compound 4, half-maximal effective concentration: 14 nM
For compound 4 the middle estimate is 3.5-fold (0.54 log units) below the measured one; measured number outside the range, above it.
By their numbers in this assay, from the lowest: compounds 2 and 3 (each within the scatter of the next); then compounds 4 and 1 (each within the scatter of the next).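

In this assay, trifluoromethyl in place of hydrogen gives a 3.5-fold higher number from compound 3 to compound 4 (0.54 log units; beyond the scatter) on the aromatic carbon next to the ring sulfur, the only step shown that touches this position. The position is thus not indifferent to substitution, although compound 4 keeps a measurable agonist effect. Nothing measured here accounts for this step.

Open, on these data alone, is how a methyl group, a chlorine atom or a nitrile on this carbon would compare. Also open, as far as these compounds go, is whether trifluoromethyl here gives a similar step alongside the 2-(trifluoromethyl)phenyl group of compound 2.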